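A few compounds are considered here, and "the series" means these few. Any claim that something is new, unique, unknown or untested is made for them only; others in the source may bear on it.

Measured in a functional assay on MDA-MB-231 cells (Homo sapiens) for inhibition, read by MTT assay, with a stated time of 72 h; a lower number here means a stronger inhibitor, a higher number a weaker inhibitor:
- Compound 1 `Nc1ccccc1NC(=O)c1ccc(CNCc2nc(-c3ccc(C(F)(F)F)cc3)no2)cc1`: 6870 nM
- Compound 2 `Nc1ccccc1NC(=O)c1ccc(CNCc2nc(-c3ccc(F)cc3)no2)cc1`: 2950 nM
- Compound 3 `O=C(NO)c1ccc(CNCc2nc(-c3ccc(C(F)(F)F)cc3)no2)cc1`: 12300 nM

Compound 3 has hydroxy on the amide-type nitrogen where compound 1 has 2-aminophenyl, and the two values lie within the scatter of each other: a 1.8-fold higher number from compound 1 to compound 3 (0.25 log units; within the scatter). Compound 2 shows a clearly lower number than compound 3.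

Compound 4 `O=C(NO)c1ccc(CNCc2nc(-c3ccc([N+](=O)[O-])cc3)no2)cc1` has not yet been measured. It differs from compound 3 by nitro in place of trifluoromethyl on an aromatic carbon.

Within the data shown here, no measured step makes this exact swap. The nearest one also replaces trifluoromethyl on an aromatic carbon: a 2.3-fold lower number from compound 1 to compound 2 (0.37 log units; beyond the scatter). That step is modest, it brings in fluoro rather than nitro, and it was seen with 2-aminophenyl on the amide-type nitrogen rather than hydroxy, so it offers only a loose guide. A small move toward a lower number in this assay is therefore expected, quite possibly none beyond the scatter. The expected change is a 1.4-fold lower number from compound 3 to compound 4 (0.14 log units; within the scatter). For compound 4 the estimate is 9000 nM, with an expected range of 3500 nM to 22000 nM.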

Compound 4, half-maximal inhibitory concentration: 9560 nM
Beside the measured number, compound 4's estimate is 1.1-fold (0.03 log units) below it; the range from low to high includes it.
By their numbers in this assay, from the lowest: compound 2; then compounds 1, 4 and 3 (each within the scatter of the next).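

In this assay, among these compounds, the swap of trifluoromethyl for nitro on this aromatic carbon, para to a large group, gives a 1.3-fold lower number from compound 3 to compound 4 (0.11 log units; within the scatter), the first reading at this position with hydroxy on the amide-type nitrogen. The entering group has different atoms and carries hydrogen-bond acceptors that trifluoromethyl lacks, yet the two compounds cannot be told apart in this assay. Nothing measured here offers a reason for this outcome.

Among the compounds shown here, the only other step at this position, a 2.3-fold lower number from compound 1 to compound 2 (0.37 log units; beyond the scatter), brought in fluoro with 2-aminophenyl on the amide-type nitrogen, so it remains open whether fluoro would do the same with hydroxy there, or nitro with 2-aminophenyl. Also open, from the compounds shown here alone, is how an amine or a carboxylic acid on this aromatic carbon would read.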